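The source may hold more compounds than are shown below. What is called first, only, known or untested is meant among the compounds shown, and "the series" means these compounds.

Compound 1 `O=C(O)c1cc(-c2ccc(-c3ccc(Cl)cc3Cl)cc2)n(-c2ccccn2)n1`: in an assay on isolated protein for inhibition of methionine--tRNA ligase, cytoplasmic (Homo sapiens) (a higher number here means a weaker inhibitor, a lower number a stronger inhibitor), compound 1 gives > 100000 nM, a limit of the assay.
Compound 2 `O=C(O)c1cc(-c2ccc(-c3ccc(Cl)cc3Cl)cc2)n(Cc2cccnc2)n1`: in this assay compound 2 gives > 100000 nM, also a limit.

Compound 2 therefore stands at the limit of the assay and not at a number. Both values shown sit there (the limit of > 100000 nM in this assay, at which 2 of the 2 values shown sit). For the measured compounds named here, the single measured step, a step that the two limits leave unreadable from compound 1 to compound 2, is accordingly of unreadable size. Compound 3 `O=C(O)Cn1nc(C(=O)O)cc1-c1ccc(-c2ccc(Cl)cc2Cl)cc1` differs from compound 2 by carboxy in place of pyridin-3-yl on a saturated chain carbon bound to an aromatic nitrogen. Going by the values given here, no readable step bears on this change: the only step, from compound 1 to compound 2, is hidden by two limits, so the data give neither direction nor size for it. Since compound 2 gives > 100000 nM as a limit, compound 3 is expected to remain at that limit as well, the step that the limit leaves unreadable from compound 2 to compound 3 being what this estimate means. The estimate for compound 3 is 150000 nM, with a range from 30000 nM to 600000 nM, and in this assay it will most likely again be reported only as a limit.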

Compound 3, half-maximal inhibitory concentration: 100000 nM
Beside the measured number, compound 3's estimate is 1.5-fold (0.18 log units) above it; the range from low to high includes it.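

In this assay, for the compounds shown here, compound 3, which carries carboxymethyl on the aromatic nitrogen, gives 100000 nM, the only value shown that is a number and not a limit. This place, on a saturated chain carbon bound to an aromatic nitrogen, therefore yields a readable value with carboxy in place of pyridin-3-yl, although that number coincides with the figure of the limit reached by the other compounds: the limit of > 100000 nM in this assay, at which 2 of the 3 values shown sit.

Carboxy in place of pyridin-3-yl gives a number no higher from compound 2 to compound 3 (the limit leaves the size open). Carboxymethyl in place of pyridin-2-yl on an aromatic nitrogen gives a number no higher from compound 1 to compound 3 (the limit leaves the size open). Neither step can be read in size, so any gain from these changes remains unmeasured.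

The compounds shown leave open whether a longer chain ending in a carboxylic acid, or an amine or a primary amide at this place, would give a clearly lower number than compound 3. They also leave open whether any change elsewhere on the shared core would do so.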